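The source may hold more compounds than are shown below. What is called first, only, known or untested is meant among the compounds shown, and "the series" means these compounds.

Measured so far in a functional assay on HeLa cells (Homo sapiens) for antiproliferative activity; on this read-out lower numbers stand for stronger inhibition and higher numbers for weaker inhibition:
Compound 1, `CO/N=C/c1c(N)ncnc1Oc1ccc2cccnc2c1`: compound 1 gives 1820 nM.
Compound 2, `CO/N=C/c1c(N)ncnc1Oc1ccc2[nH]ccc2c1`: compound 2 gives 1870 nM.
Compound 3, `CNCCO/N=C/c1c(N)ncnc1Oc1ccc2[nH]c(C)cc2c1F`: compound 3 gives 2010 nM.

All three numbers sit close together. Compound 3 has the largest of them, but its gap to compound 2 and its gap to compound 1 both lie within the usual scatter, so no ordering among the three can be read from these values. Among the measured compounds shown here, the three compounds differ from one another at several places at once, and no pair differs in a single place, so nothing measured here isolates the effect of any one change.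

Compound 4, `Cc1cc2c(F)c(Oc3ncnc(N)c3/C=N/OCC3CCCCC3)ccc2[nH]1`, is not yet measured. It differs from compound 3 in one place: cyclohexyl in place of (methylamino)methyl on a saturated chain carbon bound to an oxygen on an unsaturated carbon. For the measured compounds named here, no measured pair tests that kind of exchange on the oxime side chain. Given that the three measured compounds, with rather different substitution, all land within the scatter of one another, the step from compound 3 to compound 4 is expected to be small, a 1.3-fold lower number from compound 3 to compound 4 (0.13 log units; within the scatter), most likely within the scatter, with a slight lean toward a lower number. Compound 4 in this assay is therefore expected near 1500 nM, with a range of 500 nM to 4500 nM.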

Compound 4, half-maximal inhibitory concentration: 22700 nM
Estimate against measurement, compound 4: 15-fold (1.18 log units) below; the whole stated range lies below it.
By their numbers in this assay, from the lowest: compounds 1, 2 and 3 (each within the scatter of the next); then compound 4.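

Among the compounds shown here, the side chain on the oxime oxygen is the first place where a single change can be read: in this assay there is a large step, an 11-fold higher number from compound 3 to compound 4 (1.05 log units; beyond the scatter), with cyclohexyl in place of (methylamino)methyl. The three earlier compounds lie within the scatter of one another, but they differ in several places at once, so they could not show that this position tolerates change poorly; this pair shows that the read-out here is sensitive to the group, with the exchange going toward weaker inhibition. Nothing available indicates what underlies the step.

Still open, as far as these compounds go, is whether the step follows from the loss of the amine or the entry of the ring, which a longer unbranched carbon chain or a piperidine at the same place would help to separate. Also open, from the compounds shown here alone, is whether a carboxylic acid there, or the same exchange on a different core, would behave alike.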